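This account rests on a few compounds, and the source may have more. Where it says the series, first, only, none or still open, it means among the compounds named here.

Measured compounds in an assay on isolated protein for binding affinity to vitamin D3 receptor (Homo sapiens), with a stated time of 4 h; a lower number here means a stronger inhibitor, a higher number a weaker inhibitor:
compound 1 `CCn1c(C(=O)NCCN)ccc1C(CC)(CC)c1ccc(OCC(=O)C(C)(C)C)c(C)c1`; compound 1 gives 1010 nM
compound 2 `C#CCNC(=O)c1ccc(C(CC)(CC)c2ccc(OCC(O)C(C)(C)C)c(C)c2)n1CC`; compound 2 gives only a limit, > 10000 nM
compound 3 `CC[C@@H](C)[C@H](NC(=O)c1ccc(C(CC)(CC)c2ccc(OCC(=O)C(C)(C)C)c(C)c2)n1CC)C(=O)O`; compound 3 gives 564 nM

Among the measured compounds shown here, the only step between measured compounds, a 1.8-fold lower number from compound 1 to compound 3 (0.25 log units; within the scatter), changes the substituent on the amide-type nitrogen and stays within the scatter. Compound 2 sits at the limit of > 10000 nM in this assay, at which 1 of the 3 values shown sits, so for it no number is known, only that it lies past the limit.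

Compound 4 `CCOc1ccc(NC(=O)c2ccc(C(CC)(CC)c3ccc(OCC(O)C(C)(C)C)c(C)c3)n2CC)cc1` differs from compound 2 by 4-ethoxyphenyl in place of propargyl on an amide-type nitrogen. For the measured compounds named here, the change falls at the same place as the one measured step, which was within the scatter; that step, however, started from a compound with a measured number, while compound 2 gives only a limit, so no direction can be read from it for this pair. In this assay compound 4 is therefore expected to stay near the limit, with the step that the limit leaves unreadable from compound 2 to compound 4 expected to be small. For compound 4 the estimate is 15000 nM, with a range from 3000 nM to 60000 nM.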

Compound 4, half-maximal inhibitory concentration: 9250 nM
For compound 4 the middle estimate is 1.6-fold (0.21 log units) above the measured one; low and high end bracket the measured number.
By their numbers in this assay, from the lowest: compounds 3 and 1 (each within the scatter of the next); then compound 4. At a limit, above all of these: compound 2.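

In this assay, compound 4 gives a measured number, 9250 nM, so with 4-ethoxyphenyl on the amide-type nitrogen this hydroxy side-chain pair now has a value inside the range of the assay. Compound 2 remains only a limit, > 10000 nM. As far as these compounds go, the change reads as an at least 1.0-fold lower number from compound 2 to compound 4 (0.03 log units; that floor lies within the scatter), so the true size of the step stays unknown, and no gain beyond the scatter can be claimed.

From the compounds shown here alone, it remains open whether the ethoxy group or the aromatic ring itself matters, which a plain phenyl or a 4-methoxyphenyl on the same nitrogen would help separate. Also open is how the hydroxy side chain of compound 4 compares with the ketone side chain of compound 1 and compound 3, since no pair shown differs in that place alone.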